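The compounds below may be only part of what the source reports. "The series", "measured", "known", "first", "only" and "open" are said of these compounds alone.

The three measured compounds:
compound 1, `O/N=C(\CCN1CCN(c2ccccn2)CC1)c1cccc(F)c1`, which gives 72% in a functional assay on HEK293 cells with D(4) dopamine receptor (Homo sapiens) as the target, read by FLIPR; on this read-out lower numbers stand for smaller maximal responses and higher numbers for larger maximal responses;
compound 2, `O/N=C(\CCN1CCN(c2ccccn2)CC1)c1ccc(Cl)cc1`, which gives 46% in this assay;
compound 3, `CCO/N=C(\CCN1CCN(c2ccccc2C#N)CC1)c1ccccc1`, which gives 82% in this assay.

Compound 3 has the highest of these three numbers. Compound 1 comes nearest to it, and that gap lies within the usual scatter of repeated measurements, so the two cannot be ranked against each other; compound 2 lies furthest from compound 3, and that gap is beyond the scatter. Within the data shown here, the one step measured between compounds that differ in a single place is a number 26 percentage points lower from compound 1 to compound 2 (beyond the scatter), which concerns the aryl group on the carbon with a double bond to nitrogen.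

Compound 4, `CCO/N=C(\CCN1CCN(c2ccc(OC)cc2)CC1)c1ccccc1`, has not yet been measured. It differs from compound 3 by 4-methoxyphenyl in place of 2-cyanophenyl on an amine nitrogen in a ring. Among the measured compounds shown here, no measured pair changes the group on the amine nitrogen in the ring, so the measured step does not bear on this change and offers no direction for it. The account therefore expects compound 4 to show no step beyond the scatter, a number 7 percentage points lower from compound 3 to compound 4 (within the scatter), with wide uncertainty around that expectation. Compound 4 is expected to give 75% in this assay, estimated to fall between 45% and 100%.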

Compound 4, largest response reached (reported as efficacy), in percent of the reference or control that the assay uses: 5%
Compound 4: the middle estimate sits 70 percentage points above what was measured; the measured number lies below the stated range.
By their numbers in this assay, from the lowest: compound 4; then compound 2; then compounds 1 and 3 (each within the scatter of the next).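

Compound 4 shows that the group on the amine nitrogen in the ring can strongly change the maximal response in this assay: replacing 2-cyanophenyl with 4-methoxyphenyl gives a number 77 percentage points lower from compound 3 to compound 4 (beyond the scatter), a large step. Among these compounds, the only earlier step, a number 26 percentage points lower from compound 1 to compound 2 (beyond the scatter), was modest and concerned the aryl group on the carbon with a double bond to nitrogen, so the new result adds a second place where the response changes, one that the earlier compounds did not test. The two groups match in heavy-atom count, in their six-membered aromatic ring of carbon only, in hydrogen-bond donors and acceptors and in having no net charge, so these counts do not separate them, and no supporting data explain the drop.

This change replaces a nitrile with a methoxy group and also alters where the substituent sits on the phenyl ring, so 2-methoxyphenyl, 4-cyanophenyl or unsubstituted phenyl on the same nitrogen would be needed to separate the two effects. Going by these compounds, it also remains open whether the same change would have a similar effect with a free hydroxyl in place of the ethoxy group.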